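Cytotoxicity notes on an amide nitrogen swap

The source may report more compounds than this note shows. Statements on the series, on what has been measured and on what is new or still open speak of the compounds shown alone.

Measured in a functional assay on SK-BR-3 cells (Homo sapiens) for cytotoxicity, read by MTT assay, with a stated time of 72 h; a lower number here means a stronger inhibitor, a higher number a weaker inhibitor:
- compound 1 `Nc1ccc(Nc2c(C(=O)NCc3ccc(F)cc3)nc(Br)c3cccnc23)cc1`: 4000 nM
- compound 2 `C[C@H](NC(=O)c1nc(Br)c2cccnc2c1N[C@H]1CC[C@H](N)CC1)c1ccc(F)cc1`: 9000 nM

Compound 2, at 9000 nM, holds the higher of the two numbers in this assay. Compound 1, at 4000 nM, lies lower, and the gap goes beyond the usual scatter. The two compounds differ in more than one place, so their values do not isolate any single change.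

The next compound is compound 3 `N[C@H]1CC[C@H](Nc2c(C(=O)Nc3ccccc3)nc(Br)c3cccnc23)CC1`, which departs from compound 2 as follows: phenyl in place of 1-(4-fluorophenyl)ethyl on an amide-type nitrogen. Within the data shown here, no measured pair shows this change alone, so the expectation is weakly grounded. No step beyond the scatter is expected, with only a slight lean towards a lower number. The expected change is a 1.3-fold lower number from compound 2 to compound 3 (0.11 log units; within the scatter). Among the measured compounds shown here, the range is kept wide in both directions, as the data contain no direct precedent for the change.

For compound 3 the estimated value is 7000 nM, within an expected range from 2500 nM to 20000 nM.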

Compound 3, half-maximal inhibitory concentration: 2000 nM
Compound 3: the middle estimate sits 3.5-fold (0.54 log units) above what was measured; the whole stated range lies above it.
By their numbers in this assay, from the lowest: compounds 3 and 1 (each within the scatter of the next); then compound 2.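

In this assay, among these compounds, the amide nitrogen is the first place where a single change can be read: phenyl in place of 1-(4-fluorophenyl)ethyl gives a 4.5-fold lower number from compound 2 to compound 3 (0.65 log units; beyond the scatter), so the substituent at this position does bear on the number. The step goes with a swap from 9 heavy atoms to 6, and the fluorine and the defined stereocentre leave together, so this one pair cannot assign it to any one of these differences. No measurement at hand accounts for the step.

As far as these compounds go, what stays open is which part of 1-(4-fluorophenyl)ethyl goes with the step, a question that a pair carrying plain benzyl, 1-phenylethyl or 4-fluorophenyl on the same amide nitrogen could begin to separate. Also open, from the compounds shown here alone, are how far the trend runs with an amine or a carboxylic acid on the phenyl, or with a longer chain between the phenyl and the amide nitrogen, and whether the same swap gives a similar step on a compound with the other amine substituent seen in compound 1.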